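The source may hold more compounds than are shown below. What is called first, only, known or untested is meant among the compounds shown, and "the series" means these compounds.

Measured so far in an assay on isolated protein for inhibition of phosphatidylinositol 4,5-bisphosphate 3-kinase catalytic subunit beta isoform (Homo sapiens); on this read-out lower numbers stand for stronger inhibition and higher numbers for weaker inhibition:
compound 1 `Cc1ccc([N+](=O)[O-])cc1S(=O)(=O)N[C@H]1CCCN(Cc2cnn3ccc(C#N)cc23)C1` gives > 1000 nM, a limit of the assay.
compound 2 `Cc1ccc([N+](=O)[O-])cc1C(=O)NC1CN(Cc2cnn3ccc(C#N)cc23)C1` gives > 1000 nM, a limit of the assay.
compound 3 `Cc1ccc([N+](=O)[O-])cc1C(=O)N[C@H]1CCCN(Cc2cnn3ccc(C#N)cc23)C1` gives > 1000 nM, a limit of the assay.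

Compound 3 therefore stands on no number of its own in this assay; its value is a limit, and the same holds for the two other compounds shown, which all sit at the limit of > 1000 nM in this assay, at which 3 of the 3 values shown sit. Among the measured compounds shown here, no pair of measured compounds is connected by a single-point step, so nothing in the data tells how any change moves the read-out, nor whether the shared core carries any measurable inhibition at all.

Compound 4 `Cc1ccc([N+](=O)[O-])cc1C(=O)N[C@@H]1CCCN(Cc2cnn3ccc(C#N)cc23)C1` differs from compound 3 as follows: the two compounds have the same atoms and bonds and differ only in configuration as drawn: 1 of 1 stereo elements differ; a stereocentre at a saturated ring carbon is drawn S in compound 3 and R in compound 4. With compound 3 at a limit, the step to compound 4 cannot be anchored to a measured change. The expected step is a step that the limit leaves unreadable from compound 3 to compound 4, in no set direction, with the most likely outcome that compound 4 also reports only a limit. For compound 4 the estimate in this assay is 1500 nM, with a range from 300 nM to 10000 nM.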

Compound 4, half-maximal inhibitory concentration: > 1000 nM
Compound 4: only a limit was reported (the forecaster's own chance of this, stated with the estimate: 65%); the middle value does not contradict the limit.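

The step from compound 3 to compound 4 cannot be read in this assay, as both compounds report only a limit: the limit of > 1000 nM in this assay, at which 4 of the 4 values shown sit.

The compounds shown leave open whether the shared core carries measurable inhibition and whether the drawn configuration changes it at all.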